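Bromine on the Fused Ring of Compound 3

This account rests on a few compounds, and the source may have more. Where it says the series, first, only, none or still open, it means among the compounds named here.

Compound 3 `COc1ccc(C2=NN(C3=NC(=O)/C(=C4\C(=O)Nc5ccccc54)S3)C(c3ccc(Cl)cc3)C2)cc1` stands, together with compound 1 `COc1ccc(C2=NN(C3=NC(=O)/C(=C4\C(=O)Nc5ccccc54)S3)C(c3ccc(OC)cc3)C2)cc1`, at the top end of the numbers seen so far in a functional assay on cells (Melanoma cell, Homo sapiens) for cytotoxicity, read by sulforhodamine B assay, with a stated time of 48 h; on this read-out higher numbers stand for weaker inhibition of growth and lower numbers for stronger inhibition of growth: compound 3 gives 100000 nM, and compound 1 gives 100000 nM, the step between them being no change at the digits printed from compound 1 to compound 3 (within the scatter) on chloro in place of methoxy. Within the data shown here, the only compound far from this pair is compound 2 `COc1ccc(C2=NN(C3=NC(=O)/C(=C4\C(=O)Nc5ccc(Br)cc54)S3)C(c3ccc(OC)cc3)C2)cc1`, which in this assay gives 410 nM; that is a 240-fold lower number from compound 1 to compound 2 (2.39 log units; beyond the scatter) for bromo in place of hydrogen.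

Compound 4 `COc1ccc(C2=NN(C3=NC(=O)/C(=C4\C(=O)Nc5ccc(Br)cc54)S3)C(c3ccc(Cl)cc3)C2)cc1` carries the same alteration relative to compound 3: bromo in place of hydrogen on an aromatic carbon. Among the measured compounds shown here, one measured step bears directly on it, the one from compound 1 to compound 2, which is the same substitution on the same ring and was a 240-fold lower number from compound 1 to compound 2 (2.39 log units; beyond the scatter). The swap of chloro for methoxy gave no change at the digits printed from compound 1 to compound 3 (within the scatter), so that swap is not expected to interfere with the bromo effect. Compound 4 is therefore expected to show a large drop in this assay, on the order of a 200-fold lower number from compound 3 to compound 4 (2.30 log units; beyond the scatter). The estimate for compound 4 is 500 nM, with a range from 100 nM to 10000 nM.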

Compound 4, concentration for total growth inhibition: 340 nM
Compound 4: the middle estimate sits 1.5-fold (0.17 log units) above what was measured; measured number inside the range.
By their numbers in this assay, from the lowest: compounds 4 and 2 (each within the scatter of the next); then compounds 1 and 3 (each within the scatter of the next).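

In this assay, bromo in place of hydrogen on this aromatic carbon, meta to a fused ring and para to a fused ring, gives a 290-fold lower number from compound 3 to compound 4 (2.47 log units; beyond the scatter), so the large step is no longer tied to the core of compound 1 and recurs at nearly the same size on a second core: the same change on two cores in this assay, a 240-fold lower number (2.39 log units; beyond the scatter) from compound 1 to compound 2 and a 290-fold lower number (2.47 log units; beyond the scatter) from compound 3 to compound 4, 1.2-fold (0.08 log units) apart, within the scatter of two such steps The result also tests chloro in place of methoxy with bromo present, where the change gives a 1.2-fold lower number from compound 2 to compound 4 (0.08 log units; within the scatter), so this swap has no readable effect with either hydrogen or bromo on the fused ring: the same change on two cores in this assay, no change at the digits printed (within the scatter) from compound 1 to compound 3 and a 1.2-fold lower number (0.08 log units; within the scatter) from compound 2 to compound 4, 1.2-fold (0.08 log units) apart, within the scatter of two such steps Across these four compounds, the level of the number follows hydrogen or bromo at this position and not chloro or methoxy on the other aromatic ring, and none of the four goes against this pattern.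

The compounds shown leave open whether only bromo produces this step, or whether chloro, methyl or an amine on the same carbon would do the same. They also leave open whether the indifference to chloro or methoxy would extend to a carboxylic acid or a longer alkoxy chain in that place.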